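Thiophen-2-yl in place of phenyl: compound 4

The source may report more compounds than this note shows. Statements on the series, on what has been measured and on what is new or still open speak of the compounds shown alone.

In a functional assay on MDA-MB-231 cells (Homo sapiens) for inhibition, read by sulforhodamine B assay, with a stated time of 74 h (on this read-out lower numbers stand for stronger inhibition and higher numbers for weaker inhibition), compound 1 (`O=C1C=CC2(C=C1)OCC(=O)N2S(=O)(=O)c1ccccc1`) gives > 10000 nM, which is a limit and not a number. Compound 2 (`O=C1C=CC2(C=C1)OCC(=O)N2S(=O)(=O)c1ccc([N+](=O)[O-])cc1`) gives > 10000 nM, also a limit. Compound 3 (`O=C1C=CC2(C=C1)OCC(=O)N2S(=O)(=O)c1cccc(C(F)(F)F)c1`) gives > 10000 nM, again a limit. Within the data shown here, compound 1 therefore has no measured number to start from, and the series so far is summed up by the limit of > 10000 nM in this assay, at which 3 of the 3 values shown sit.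

Compound 4 (`O=C1C=CC2(C=C1)OCC(=O)N2S(=O)(=O)c1cccs1`) carries thiophen-2-yl in place of phenyl on a sulfonyl sulfur.

Two measured changes on the same aromatic ring bear on this. Nitro in place of hydrogen on an aromatic carbon gives a step that the two limits leave unreadable from compound 1 to compound 2. Adding trifluoromethyl to that ring gives a step that the two limits leave unreadable from compound 1 to compound 3. Neither has a readable size, so neither supports a direction, and no step beyond the scatter is expected in this assay. The expected change is a number no higher from compound 1 to compound 4 (the limit leaves the size open). Another reading at the limit is the likeliest result. For compound 4 the estimated half-maximal inhibitory concentration is 10000 nM, with an expected range of 3000 nM to 30000 nM.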

Compound 4, half-maximal inhibitory concentration: 20 nM
Compound 4: the middle estimate sits 500-fold (2.70 log units) above what was measured; measured number below the stated range.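

In this assay, thiophen-2-yl in place of phenyl on a sulfonyl sulfur gives an at least 500-fold lower number from compound 1 to compound 4 (2.69 log units; beyond the scatter), so this position can move the read-out strongly. Among these compounds, the steps to compound 2 and compound 3 cannot be read, which makes replacing the aromatic ring itself the first change here with a readable size. Compound 4 is the only compound shown with a measured number, set against a series otherwise held at the assay limit: the limit of > 10000 nM in this assay, at which 3 of the 4 values shown sit.

The change replaces a six-membered ring of carbon only with a five-membered ring holding a sulfur, and the compounds shown do not separate these two differences. Furan-2-yl would test whether the sulfur matters, while a chlorine on the thiophen-2-yl ring would show whether this ring accepts further substitution.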